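This account rests on a few compounds, and the source may have more. Where it says the series, first, only, none or still open, it means among the compounds named here.

Measured so far:
- compound 1, `CCC1(Cc2ccccc2)OS(=O)(=O)C=C1OCCc1ccccc1` — 48000 nM
- compound 2, `CCC1(Cc2ccccc2)OS(=O)(=O)C=C1OCc1ccc(C(C)(C)C)cc1` — 200000 nM

Both compounds were tested in an ADME assay on HEL cells (Homo sapiens) for cytotoxicity, with a stated time of 3 days; on this read-out lower numbers stand for higher toxicity in this test and higher numbers for lower toxicity in this test. Of the two numbers available, compound 2 gives the higher one; its gap to compound 1 lies beyond the usual scatter, so compound 2 is the less toxic of the pair on this read-out. For the measured compounds named here, no pair of measured compounds differs in only one place, so no single-change step is available to lean on.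

Compound 3, `CCC1(Cc2ccccc2)OS(=O)(=O)C=C1OCc1ccc(C)cc1`, has not yet been tested. It differs from compound 2 by methyl in place of tert-butyl on an aromatic carbon. Going by these compounds, the effect of trimming this group at that site is unknown from the measured compounds: the two values at hand show only that a different substituent pattern at this end of the molecule can shift the number considerably. Compound 3 is therefore expected to stay in the range spanned by compounds 1 and 2, with the step of a 1.7-fold lower number from compound 2 to compound 3 (0.22 log units; within the scatter) estimated as a moderate move toward compound 1. The estimate for compound 3 in this assay is 120000 nM, within 40000 nM to 300000 nM.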

Compound 3, half-maximal cytotoxic concentration: 41500 nM
Compound 3: the middle estimate sits 2.9-fold (0.46 log units) above what was measured; the range from low to high includes it.
By their numbers in this assay, from the lowest: compounds 3 and 1 (each within the scatter of the next); then compound 2.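

In this assay, for the compounds shown here, tert-butyl giving way to methyl on an aromatic carbon, para to a large group, produces a 4.8-fold lower number from compound 2 to compound 3 (0.68 log units; beyond the scatter) and so gives the first single-change reading at this site, one that runs toward higher toxicity in this test. The swap of benzyl for 4-methylphenyl on a saturated chain carbon bound to an oxygen on an unsaturated carbon produces a 1.2-fold lower number from compound 1 to compound 3 (0.06 log units; within the scatter) and stays within the scatter, so this change does not separate the two compounds on this read-out. Among the three compounds shown, compound 2 with its tert-butyl group is thus the only one that stands clear of the others, while compound 1 and compound 3 cannot be told apart.

Going by these compounds, whether isopropyl, methoxy or a carboxylic acid on that same aromatic carbon would read like compound 2 or like compound 3 remains open. Also open, on these data alone, is whether tert-butyl would raise the number to a similar extent on the aromatic ring of compound 1. Nothing available bears on the reason for these results.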